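The source may hold more compounds than are shown below. What is called first, only, known or untested is meant among the compounds shown, and "the series" means these compounds.

Measured so far:
Compound 1, `c1cnc2c(c1)CCC[C@@H]2N(CC1CC1)C[C@H]1Cc2c(cccc2N2CCNCC2)CN1`, gives > 30000 nM in a functional assay on CCRF-CEM cells for agonist activity at C-X-C chemokine receptor type 4 (Homo sapiens), read by calcium flux, with a stated time of 25 min (on this read-out higher numbers stand for an effect only at larger amounts of compound and lower numbers for an effect already at smaller amounts), a limit of the assay rather than a number.
Compound 2, `Cc1cnc(CN(C)C[C@H]2Cc3c(cccc3N3CCNCC3)CN2)c(C)c1`, gives > 30000 nM in this assay, again a limit.
Compound 3, `CC(C)N1CCN(c2cccc3c2C[C@H](CN(C)[C@H]2CCCc4cccnc42)NC3)CC1`, gives > 30000 nM in this assay, also a limit.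

Compound 3 therefore stands nowhere in particular among the shown values: all three sit at the limit of > 30000 nM in this assay, at which 3 of the 3 values shown sit, and none of them separates from the others. Compound 4, `CCN1CCN(c2cccc3c2C[C@H](CN(C)[C@H]2CCCc4cccnc42)NC3)CC1`, differs from compound 3 in one place: hydrogen in place of methyl on a saturated chain carbon bound to an amine nitrogen in a ring and a saturated chain carbon. No step between measured compounds is shown, so nothing in these data says how a change of this kind moves the read-out in this assay. With every shown value at the limit and no measured step to lean on, the step of a number no higher from compound 3 to compound 4 (the limit leaves the size open) is expected to be none beyond the scatter. Compound 4 is thus expected to give about 30000 nM in this assay, most likely reported again as a limit, with a range from 10000 nM to 100000 nM.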

Compound 4, half-maximal effective concentration: > 30000 nM
Compound 4 ended at the assay's limit; the forecaster's own chance of this, stated with the estimate: 85%; the middle value sits exactly at the limit.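

Within the data shown here, no step from compound 3 to compound 4 can be read, since the values of both compounds are limits of the assay rather than numbers: the limit of > 30000 nM in this assay, at which 4 of the 4 values shown sit.
In this assay the compounds shown leave open whether any of them has a measurable half-maximal effective concentration, and how swapping isopropyl for ethyl moves it.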